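Benzyloxymethylamino series: swapping the benzyl group for isopentyl

The source may hold more compounds than are shown below. What is called first, only, known or untested is meant among the compounds shown, and "the series" means these compounds.

Measured compounds:
- compound 1 `O=[N+]([O-])c1cccc(COCNc2n[n+]([O-])c3ccccc3[n+]2[O-])c1`: 3070 nM
- compound 2 `[O-][n+]1nc(NCOCc2ccccc2)[n+]([O-])c2ccccc21`: 13400 nM
- compound 3 `CC(OCNc1n[n+]([O-])c2ccccc2[n+]1[O-])c1ccccc1`: 6080 nM

In a functional assay on PC-3 cells (Homo sapiens) for cytotoxicity, read by MTT assay, with a stated time of 72 h (a higher number here means a weaker inhibitor, a lower number a stronger inhibitor), compound 2 gives the highest number of the three, so it is the weakest inhibitor among the measured compounds. The step of a 4.4-fold higher number from compound 1 to compound 2 (0.64 log units; beyond the scatter) and the step of a 2.2-fold lower number from compound 2 to compound 3 (0.34 log units; beyond the scatter) both move away from compound 2 toward lower numbers, though each is modest.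

Compound 4 `CC(C)CCOCNc1n[n+]([O-])c2ccccc2[n+]1[O-]` is not yet measured. It differs from compound 2 by isobutyl in place of phenyl on a saturated chain carbon bound to an oxygen on a saturated carbon. Neither measured step bears directly on this change: one removes a nitro group from the ring, the other adds a methyl to the chain, and none exchanges the aromatic ring for an alkyl chain. The two measured steps were modest in size, and the present change removes the ring entirely, so no firm direction can be read from them. An expected step of a 1.1-fold lower number from compound 2 to compound 4 (0.05 log units; within the scatter) in this assay is therefore essentially no change beyond the scatter, with wide uncertainty. Compound 4 is estimated at 12000 nM, in the range 4000 nM to 36000 nM.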

Compound 4, half-maximal inhibitory concentration: 11100 nM
Compound 4: middle estimate off by 1.1-fold (0.03 log units), on the high side; the measured number falls inside the stated range.
By their numbers in this assay, from the lowest: compounds 1, 3, 4 and 2 (each within the scatter of the next, the first and the last beyond it).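

In this assay, isobutyl in place of phenyl on a saturated chain carbon bound to an oxygen on a saturated carbon gives a 1.2-fold lower number from compound 2 to compound 4 (0.08 log units; within the scatter), so the benzyl-to-isopentyl exchange leaves the reading within the scatter. The earlier steps shown here kept the aromatic ring and changed only a substituent on the ring or the chain, whereas this pair shows that, at this place and with this core, the ring can be lost entirely without a change beyond the scatter. No available data explain why these two groups read alike.

Open, from the compounds shown here alone, is whether a longer chain, an amine or a carboxylic acid at this place would move the number beyond the scatter. Also open, going by these compounds, is whether a nitro group or an added chain methyl would carry the same steps in a series without the ring.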